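A few compounds are considered here, and "the series" means these few. Any claim that something is new, unique, unknown or untested is made for them only; others in the source may bear on it.

Measured compounds:
compound 1, `Cc1nc2c(OCc3ccccc3)cccn2c1N`: 6.81
compound 2, `Cc1c(C(F)(F)F)nc2c(OCc3ccccc3)cccn12`: 2

In a physicochemical assay for acid dissociation, compound 1 gives 6.81, the higher of the two numbers, while compound 2 gives 2, far lower and well beyond the usual scatter. Compound 3, `Cc1nc2c(OCc3ccccc3)cccn2c1CO`, differs from compound 1 in one place: hydroxymethyl in place of amino on an aromatic carbon. Within the data shown here, no step between measured compounds matches this exchange, so the expectation rests on compound 1 alone. A moderate fall is expected for this change, a number 1.01 log units lower from compound 1 to compound 3 (beyond the scatter). Compound 3 is estimated at 5.8, within a range from 5 to 6.6.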

Compound 3, acid dissociation constant: 6.1
Compound 3: the middle estimate sits 0.30 log units below what was measured; measured number inside the range.
By their numbers in this assay, from the lowest: compound 2; then compound 3; then compound 1.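

In this assay, hydroxymethyl in place of amino on this aromatic carbon gives a number 0.71 log units lower from compound 1 to compound 3 (beyond the scatter) as the first step read at this position, so the number does respond to this exchange, though modestly. Both groups count one hydrogen-bond donor and one hydrogen-bond acceptor, so the number moves even though those counts stay the same. Nothing measured here accounts for the step. Still open, from the compounds shown here alone, is how a carboxylic acid, a methylamine or a longer chain such as hydroxyethyl on this carbon would compare with compound 1 and compound 3.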